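The source may report more compounds than this note shows. Statements on the series, on what has been measured and on what is new or still open speak of the compounds shown alone.

- Compound 1 `COCCN[C@H]1CC[C@H](Nc2cc(-c3csc(SCC4CCOCC4)n3)c(Cl)cn2)CC1`: 340 nM
- Compound 2 `COCCN[C@H]1CC[C@H](Nc2cc(-c3csc(NCC4CC4)n3)c(Cl)cn2)CC1`: 740 nM

In a functional assay on MV4-11 cells (Homo sapiens) for antiproliferative activity, read by CellTiter-Glo, with a stated time of 72 h (a higher number here means a weaker inhibitor of growth, a lower number a stronger inhibitor of growth), compound 2 gives 740 nM, the higher and therefore weaker of the two numbers. Compound 3 `COCCN[C@H]1CC[C@H](Nc2cc(-c3csc(NCc4ccccc4)n3)c(Cl)cn2)CC1` differs from it by phenyl in place of cyclopropyl on a saturated chain carbon bound to a nitrogen on an aromatic ring. Among the compounds with values here, the only measured step changes the same part of the molecule, though not in this way: a 2.2-fold higher number from compound 1 to compound 2 (0.34 log units; beyond the scatter). That modest step suggests a similarly small change here, with no clear direction, although a slight gain in this assay seems marginally more likely. The expected step is a 1.3-fold lower number from compound 2 to compound 3 (0.13 log units; within the scatter). For compound 3, the estimated value is 550 nM, with an expected range of 180 nM to 1600 nM.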

Compound 3, concentration for 50% growth inhibition: 330 nM
Estimate against measurement, compound 3: 1.7-fold (0.22 log units) above; measured number inside the range.
By their numbers in this assay, from the lowest: compounds 3 and 1 (each within the scatter of the next); then compound 2.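

In this assay, phenyl in place of cyclopropyl on the saturated chain carbon gives a real gain (a 2.2-fold lower number from compound 2 to compound 3 (0.35 log units; beyond the scatter)), so the end of this amino side chain affects growth inhibition. Benzylamino in place of ((oxan-4-yl)methyl)sulfanyl changes little (a 1.0-fold lower number from compound 1 to compound 3 (0.01 log units; within the scatter)), so here a nitrogen-linked group matches the sulfur-linked one. No supporting measurement explains either result.

On these data alone, whether a longer chain, as in 2-phenylethylamino, would keep this level remains open. So does the effect of a fluorine or a methoxy group on the phenyl ring.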